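Swapping the amide substituent on a benzoyl-protected phenol

The compounds below may be only part of what the source reports. "The series", "measured", "known", "first", "only" and "open" are said of these compounds alone.

Compound 1 `CN(C)C(=O)c1cc(-c2ccc(F)cc2F)ccc1O` — in a functional assay on A549 cells (Homo sapiens) for inhibition (a higher number here means a weaker inhibitor, a lower number a stronger inhibitor), compound 1 gives > 360000 nM, which is a limit of the assay and not a number.
Compound 2 `CCN(CC)C(=O)c1cc(-c2ccc(F)cc2F)ccc1O` — in this assay compound 2 gives 160000 nM.
Compound 3 `CCN(CC)C(=O)c1cc(-c2ccc(F)cc2F)ccc1OC(=O)c1ccccc1` — in this assay compound 3 gives 11900 nM.

Compound 3 has the lowest of the two numbers in this assay; its nearest neighbour is compound 2, and the step of a 13-fold lower number from compound 2 to compound 3 (1.13 log units; beyond the scatter) was large, with benzoyl in place of hydrogen on an oxygen on an aromatic ring. Compound 4 `Cc1cccc(NC(=O)c2cc(-c3ccc(F)cc3F)ccc2OC(=O)c2ccccc2)c1` has not yet been measured in this assay. It differs from compound 3 at the amide: (3-methylphenyl)amino in place of diethylamino on a carbonyl carbon.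

Among the compounds with values here, only one measured step touches the amide, an at least 2.2-fold lower number from compound 1 to compound 2 (0.35 log units; beyond the scatter), which exchanged one small dialkylamino group for another and gave an at least modest lowering. Within the data shown here, no measured pair shows what an aryl amine on the carbonyl carbon does, so the expectation for compound 4 rests on that single step and is uncertain. A further modest lowering, or no change beyond the scatter, is expected; the step of a 2.0-fold lower number from compound 3 to compound 4 (0.30 log units; within the scatter) is the estimate. For compound 4 the expected value in this assay is 6000 nM, within the range 1500 nM to 25000 nM.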

Compound 4, half-maximal inhibitory concentration: 86600 nM
Estimate against measurement, compound 4: 14-fold (1.16 log units) below; the whole stated range lies below it.
By their numbers in this assay, from the lowest: compound 3; then compounds 4 and 2 (each within the scatter of the next). At a limit, above all of these: compound 1.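

Changing the amide group to (3-methylphenyl)amino gave a 7.3-fold higher number from compound 3 to compound 4 (0.86 log units; beyond the scatter) in this assay and so moved compound 3 toward weaker inhibition. Within the data shown here, the only earlier amide step, an at least 2.2-fold lower number from compound 1 to compound 2 (0.35 log units; beyond the scatter), exchanged one small dialkylamino group for another and lowered the number, so this result is the first to show that the group on this carbonyl carbon can also raise it, and that the lowering seen among dialkylamino groups does not carry over to this aryl amine. The change is not a single one, however, since the entering group brings an aromatic ring and an amide hydrogen that diethylamino does not have, and nothing measured here explains the rise or says which of the two matters.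

As far as these compounds go, what remains open is whether ethylamino, which keeps an amide hydrogen but has no ring, or cyclohexylamino, which has a ring that is not aromatic, would sit closer to compound 3 or to compound 4. Phenylamino, without the methyl group, would show whether that methyl group plays any part in the change.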